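Swapping the sulfonyl substituent on a protected glycal sulfonamide

This account rests on a few compounds, and the source may have more. Where it says the series, first, only, none or still open, it means among the compounds named here.

Measured compounds:
compound 1, `CCS(=O)(=O)N[C@@H]1C=C[C@H](OC(C)=O)[C@@H](COC(C)=O)O1`, 280000000 nM
compound 2, `CC(=O)OC[C@H]1O[C@H](NS(N)(=O)=O)C=C[C@H]1OC(C)=O`, 558000000 nM
compound 3, `CC(=O)OC[C@H]1O[C@H](NS(=O)(=O)c2ccc(C)cc2)C(OC(C)=O)=C[C@@H]1OC(C)=O`, 34900000 nM

The three compounds were tested in a functional assay on A549 cells (Homo sapiens) for cytotoxicity, read by MTT assay, with a stated time of 24 h; on this read-out higher numbers stand for weaker inhibition and lower numbers for stronger inhibition. Compound 1 gives the second highest of the three numbers. Its nearest neighbour is compound 2, whose number is within the usual scatter of that of compound 1, so the two cannot be told apart. Compound 3 stands furthest away, with a number clearly lower than that of compound 1, beyond the scatter.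

Compound 4, `CC(=O)OC[C@H]1O[C@H](NS(=O)(=O)c2ccc(C)cc2)C=C[C@@H]1OC(C)=O`, has not yet been measured in this assay. It differs from compound 1 in one place: 4-methylphenyl in place of ethyl on a sulfonyl sulfur. Compound 3, which also carries the 4-methylphenyl group on its sulfonyl sulfur, gives 34900000 nM in this assay, the lowest of the three numbers. On that basis compound 4 is expected to give a lower number than compound 1, a step of a 4.7-fold lower number from compound 1 to compound 4 (0.67 log units; beyond the scatter) in this assay, though compound 3 also carries a further acetate not present in compound 4, so the comparison is indirect. The estimate for compound 4 is 60000000 nM, with a range from 20000000 nM to 200000000 nM.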

Compound 4, half-maximal inhibitory concentration: 829000000 nM
Beside the measured number, compound 4's estimate is 14-fold (1.14 log units) below it, outside the stated range (above it).
By their numbers in this assay, from the lowest: compound 3; then compounds 1, 2 and 4 (each within the scatter of the next, the first and the last beyond it).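

In this assay, 4-methylphenyl in place of ethyl on the sulfonyl sulfur gives a 3.0-fold higher number from compound 1 to compound 4 (0.47 log units; beyond the scatter) and so does not by itself bring the low number of compound 3. The low number instead depends on the further acetoxy group on the double-bonded ring carbon of compound 3, as hydrogen in its place gives a 24-fold higher number from compound 3 to compound 4 (1.38 log units; beyond the scatter) in a large step. Nothing measured here accounts for either step.

On these data alone, it remains open whether the acetoxy group on that ring carbon would lower the number in the same way with ethyl on the sulfonyl sulfur, and whether a hydroxyl group there would do the same. Also open, as far as these compounds go, is how a longer alkyl chain, or a phenyl ring bearing a carboxylic acid or an amine, would behave on the sulfonyl sulfur.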